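Trimming the morpholine amide: what to expect

The compounds below may be only part of what the source reports. "The series", "measured", "known", "first", "only" and "open" are said of these compounds alone.

Measured compounds and their numbers:
Compound 1 `COc1cc(C(=O)NCc2cccc(Cl)c2)cc2nn(CCn3cccn3)cc12`, 464 nM
Compound 2 `COc1cc(C(=O)N2CCC(O)C(C)C2)cc2nc(N[C@H](C)c3cccc(Cl)c3)oc12`, 48 nM
Compound 3 `COc1cc(C(=O)N2CC(C)(CCO)OC[C@H]2C)cc2nc(N[C@H](C)c3cccc(Cl)c3)oc12`, 0.5 nM

These three were tested in an assay on isolated protein for inhibition of thyroid hormone receptor beta (Homo sapiens), read by fluorescence, with a stated time of 30 min; on this read-out higher numbers stand for weaker inhibition and lower numbers for stronger inhibition. Compound 3 has the lowest number of the three, with compound 2 nearest and compound 1 furthest away. For the measured compounds named here, the one single-place step in the set is a 96-fold lower number from compound 2 to compound 3 (1.98 log units; beyond the scatter), showing that exchanging the ring attached to the carbonyl carbon can shift the number a great deal.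

Compound 4 `COc1cc(C(=O)N2CC(C)OCC2CO)cc2nc(N[C@H](C)c3cccc(Cl)c3)oc12` has not yet been tested. It differs from compound 3 in one place: 5-(hydroxymethyl)-2-methylmorpholin-4-yl in place of 2-(2-hydroxyethyl)-2,5-dimethylmorpholin-4-yl on a carbonyl carbon. The ring keeps its single hydrogen-bond donor and two acceptors but loses two carbons, and the hydroxyl-bearing chain and the methyl groups sit differently on the ring.

Going by the values given here, the only step that bears on this is the large one from compound 2 to compound 3, which shows this ring region to be sensitive but does not say which of its features carried the gain. A moderate loss is therefore expected for compound 4, with a 10-fold higher number from compound 3 to compound 4 (1.00 log units; beyond the scatter). The estimate for compound 4 in this assay is 5 nM, within the range 1 nM to 30 nM.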

Compound 4, half-maximal inhibitory concentration: 10 nM
For compound 4 the middle estimate is 2.0-fold (0.30 log units) below the measured one; the measured number falls inside the stated range.
By their numbers in this assay, from the lowest: compound 3; then compound 4; then compound 2; then compound 1.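

In this assay, the smaller ring gives up much of the standing of compound 3, with a 20-fold higher number from compound 3 to compound 4 (1.30 log units; beyond the scatter) on the carbonyl carbon, although both rings count the same hydrogen-bond donors and acceptors. Those counts alone therefore do not set the number at this position, and the loss of carbon atoms or their arrangement matters here. The smaller morpholine still compares well with the piperidine ring, with a 4.8-fold lower number from compound 2 to compound 4 (0.68 log units; beyond the scatter) for 5-(hydroxymethyl)-2-methylmorpholin-4-yl in place of 4-hydroxy-3-methylpiperidin-1-yl, so among these three amides, the order runs from the larger morpholine through the smaller morpholine to the piperidine, but no measurement here explains why the numbers move in this way.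

The step from compound 3 to compound 4 shortens the hydroxyl-bearing chain, removes a methyl group and rearranges the groups on the ring all at once, and the compounds shown do not separate these changes. They also leave open how this position would respond to an amine or a carboxylic acid in place of the hydroxyl, or to a longer chain ending in a hydroxyl.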